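Chloro Additions on the Benzyloxy Amide and MCF7 Growth

The compounds below may be only part of what the source reports. "The series", "measured", "known", "first", "only" and "open" are said of these compounds alone.

Compound 1 `Cc1ccc(-c2nn(-c3ccccc3)cc2C(=O)NOCc2ccccc2)cc1` carries an unsubstituted benzyloxy amide. In a functional assay on MCF7 cells (Homo sapiens) for antiproliferative activity, read by MTT assay, with a stated time of 48 h, in the presence of a further agent that is not named here (a higher number here means a weaker inhibitor of growth, a lower number a stronger inhibitor of growth), compound 1 gives 1870 nM. Compound 2 `Cc1ccc(-c2nn(-c3ccccc3)cc2C(=O)NOCc2ccccc2Cl)cc1` differs from it by chloro in place of hydrogen on an aromatic carbon; this gave a 1.4-fold higher number from compound 1 to compound 2 (0.15 log units; within the scatter), and in this assay compound 2 gives 2640 nM. Compound 3 `COc1ccc(-c2nn(-c3ccccc3)cc2C(=O)NOCc2ccccc2Cl)cc1` is compound 2 with methoxy in place of methyl on an aromatic carbon; that step was a 1.4-fold higher number from compound 2 to compound 3 (0.15 log units; within the scatter), and in this assay compound 3 gives 3730 nM. The difference between compound 1 and compound 3 as cores is not broken down here. Compound 4 `COc1ccc(-c2nn(-c3ccccc3)cc2C(=O)NOCc2ccc(Cl)cc2Cl)cc1`, not yet measured, differs from compound 3 by chloro in place of hydrogen on an aromatic carbon. Going by the values given here, this is the same kind of change as the one leading to compound 2, not the same: the first chloro entered ortho to a large group, while this one enters meta to a chloro group and para to a large group. For compound 4 the expected step, set beside a 1.4-fold higher number from compound 1 to compound 2 (0.15 log units; within the scatter), is a 1.3-fold higher number from compound 3 to compound 4 (0.11 log units; within the scatter), because the earlier chloro step a 1.4-fold higher number from compound 1 to compound 2 (0.15 log units; within the scatter) stayed within the scatter. Compound 4 is therefore estimated at 4800 nM in this assay, between 2500 nM and 9500 nM.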

Compound 4, concentration for 50% growth inhibition: 2570 nM
Estimate against measurement, compound 4: 1.9-fold (0.27 log units) above; the measured number falls inside the stated range.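

Adding the chloro that turns (2-chlorobenzyl)oxy into (2,4-dichlorobenzyl)oxy gave a 1.5-fold lower number from compound 3 to compound 4 (0.16 log units; within the scatter) in this assay, so this step on the core of compound 3 stays as modest as the first chloro step on the core of compound 1. Set side by side, the two steps do not differ beyond what repeated measurement allows: the same change on two cores in this assay, a 1.4-fold higher number (0.15 log units; within the scatter) from compound 1 to compound 2 and a 1.5-fold lower number (0.16 log units; within the scatter) from compound 3 to compound 4, 2.0-fold (0.31 log units) apart, within the scatter of two such steps

This shows no detectable dependence on the core across these two pairs, but it does not show that the change carries over reliably, since each step lies within the scatter, the chloro enters a different ring environment in each pair, and so neither an effect of chloro nor a difference between the cores is established.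

The compounds shown leave open whether a nitrile, a trifluoromethyl or an amine on the benzyl ring would move the number beyond the scatter. They also leave open how the core of compound 1 would respond to the (2,4-dichlorobenzyl)oxy group.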